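Aryl swap on the chain of compound 2

The compounds below may be only part of what the source reports. "The series", "measured", "known", "first", "only" and "open" are said of these compounds alone.

compound 1 `COc1ccc(Br)cc1CCc1c(F)cccc1C(=O)/N=C(\N)NCCCCN(C)Cc1ccccc1` — 180 nM
compound 2 `CCN(CC)CCCC(C)/N=C(/N)NC(=O)c1cccc(F)c1CCc1ccc2ccccc2c1` — 1800 nM
compound 3 `COc1ccc(Br)cc1CCc1c(F)cccc1C(=O)/N=C(\N)NCCCCN1CCCCC1` — 70 nM

In a functional assay for antagonist activity at Melanocortin receptor 4 (Homo sapiens), read by cAMP accumulation (a higher number here means a weaker inhibitor, a lower number a stronger inhibitor), compound 2 gives 1800 nM, the highest of the three numbers. Compound 1 lies a clear distance lower at 180 nM. Compound 3 lies lower still at 70 nM. For the measured compounds named here, the one step measured so far, a 2.6-fold lower number from compound 1 to compound 3 (0.41 log units; beyond the scatter), concerns only the amine end of the chain.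

Compound 4 `CCN(CC)CCCC(C)/N=C(/N)NC(=O)c1cccc(F)c1CCc1cc(Br)ccc1OC` differs from compound 2 in a single place: 5-bromo-2-methoxyphenyl in place of naphthalen-2-yl on a saturated chain carbon, two bonds along the chain from an aromatic carbon. Going by the values given here, no measured step bears directly on this change, since the step between compound 1 and compound 3 leaves the aryl group untouched. Compounds 1 and 3 do carry the entering group, and both give lower numbers than compound 2, but they also differ from it at the amine end, so their values only hint at the direction.

Compound 4 is therefore expected to give a lower number than compound 2 in this assay, estimated at 600 nM, with a range of 150 nM to 2500 nM. The step expected is a 3.0-fold lower number from compound 2 to compound 4 (0.48 log units; beyond the scatter).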

Compound 4, half-maximal inhibitory concentration: 130 nM
Compound 4: the middle estimate sits 4.6-fold (0.66 log units) above what was measured, outside the stated range (below it).
By their numbers in this assay, from the lowest: compounds 3, 4 and 1 (each within the scatter of the next, the first and the last beyond it); then compound 2.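

At this place, on a saturated chain carbon, two bonds along the chain from an aromatic carbon, the aryl group alone moves the number in this assay: 5-bromo-2-methoxyphenyl in place of naphthalen-2-yl gives a 14-fold lower number from compound 2 to compound 4 (1.14 log units; beyond the scatter), a large step. For the compounds shown here, the only earlier step, a 2.6-fold lower number from compound 1 to compound 3 (0.41 log units; beyond the scatter), is modest and left the aryl group untouched, so this is the first direct reading of the aryl position. No supporting data bear on why the step is this large.

Still open, going by these compounds, is whether the bromine, the methoxy group or the loss of the second aromatic ring carries the step, which an unsubstituted phenyl or a 2-methoxyphenyl would help separate. Also open, on these data alone, is whether the same aryl swap holds with a piperidin-1-yl amine end.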